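Hydroxymethyl in Place of Fluoro: A Step Expected to Be Small

The source may report more compounds than this note shows. Statements on the series, on what has been measured and on what is new or still open speak of the compounds shown alone.

Of the compounds shown here, three have been measured in an assay on 1321N1 cells for antagonist activity at P2Y purinoceptor 6 (Homo sapiens), read by FLIPR and calcium flux; a higher number here means a weaker inhibitor, a lower number a stronger inhibitor. Compound 1 `O=[N+]([O-])C1=Cc2ccc(Cl)cc2OC1C(F)(F)F` gives 7980 nM, compound 2 `O=[N+]([O-])C1=Cc2cc(C#Cc3ccc(F)cc3)ccc2OC1C(F)(F)F` gives 8860 nM, and compound 3 `O=[N+]([O-])C1=Cc2cc(I)ccc2OC1C1CCC1` gives 33100 nM in this assay. Compound 2 holds the second highest of the three numbers; its nearest neighbour is compound 1, whose number lies within the scatter of it, and its furthest is compound 3, whose higher number lies beyond the scatter. Compound 4 `O=[N+]([O-])C1=Cc2cc(C#Cc3ccc(CO)cc3)ccc2OC1C(F)(F)F` has not yet been measured. It differs from compound 2 in one place: hydroxymethyl in place of fluoro on an aromatic carbon. Among the measured compounds shown here, no pair of measured compounds differs by this change alone, so there is no measured step to rest on; the shared core of compound 2 is kept, and only the 4-fluorophenyl group becomes 4-(hydroxymethyl)phenyl. The step from compound 2 to compound 4 in this assay is therefore expected to be small, within the scatter, in no firm direction: a 1.1-fold lower number from compound 2 to compound 4 (0.04 log units; within the scatter) is the estimated step. Compound 4 is expected to give about 8000 nM in this assay, between 3000 nM and 25000 nM.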

Compound 4, half-maximal inhibitory concentration: 2000 nM
Compound 4: the middle estimate sits 4.0-fold (0.60 log units) above what was measured; the whole stated range lies above it.
By their numbers in this assay, from the lowest: compound 4; then compounds 1 and 2 (each within the scatter of the next); then compound 3.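

The position para to a large group, on the six-membered aromatic ring, turns out to respond in this assay: hydroxymethyl in place of fluoro gives a 4.4-fold lower number from compound 2 to compound 4 (0.65 log units; beyond the scatter), a modest step that lies beyond the scatter. The earlier compounds shown here could not show this, since no two of them differed in one place, and none carried hydroxymethyl. The entering group brings a hydrogen-bond donor and acceptor where fluoro had neither, but nothing measured here connects either feature to the step.

The compounds shown leave open whether the step depends on the hydroxyl oxygen or on the added carbon, which a methoxymethyl group, an aminomethyl group or a carboxylic acid at the same place could help to separate. They also leave open whether the same change gives a similar step on a core carrying cyclobutyl instead of trifluoromethyl.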